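Benzyl on the Phenolic Oxygen of a Flavone Series

The source may report more compounds than this note shows. Statements on the series, on what has been measured and on what is new or still open speak of the compounds shown alone.

Among the compounds with values here, in a functional assay on BCG823 cells (Homo sapiens) for antiproliferative activity, read by MTT assay, with a stated time of 48 h (a higher number here means a weaker inhibitor, a lower number a stronger inhibitor), compound 2 `CN1CCN(CCCCOc2c(O)cc3oc(-c4ccccc4)cc(=O)c3c2O)CC1` gives 82900 nM, the highest of the two numbers so far. Within the data shown here, compound 1 `O=c1cc(-c2ccccc2)oc2cc(OCc3ccccc3)c(OCCCN3CCCCC3)c(O)c12` gives 4600 nM, a lower number beyond the scatter, though the two compounds differ in more than one place and no single step connects them. Compound 3 `CN1CCN(CCCCOc2c(OCc3ccccc3)cc3oc(-c4ccccc4)cc(=O)c3c2O)CC1` carries benzyl in place of hydrogen on an oxygen on an aromatic ring. Because compound 1 with its benzyloxy group gives 4600 nM, a move to a lower number is expected, which should show as a 6.9-fold lower number from compound 2 to compound 3 (0.84 log units; beyond the scatter). Compound 3 is therefore expected at 12000 nM, with a range from 3500 nM to 40000 nM.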

Compound 3, half-maximal inhibitory concentration: 7200 nM
The estimate for compound 3 lay 1.7-fold (0.22 log units) above the measured number; the range from low to high includes it.
By their numbers in this assay, from the lowest: compounds 1 and 3 (each within the scatter of the next); then compound 2.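

Benzyl in place of hydrogen on an oxygen on an aromatic ring gives a 12-fold lower number from compound 2 to compound 3 (1.06 log units; beyond the scatter) in this assay and so provides a single-place reading of hydroxy to benzyloxy, which the earlier pair could not give. With benzyloxy present, the step of a 1.6-fold higher number from compound 1 to compound 3 (0.19 log units; within the scatter) comes with (4-methylpiperazin-1-yl)methyl in place of piperidin-1-yl on a saturated chain carbon, so that change shows no effect beyond the scatter. Nothing at hand gives a reason for either step. As far as these compounds go, whether methyl, chlorobenzyl or phenethyl on that oxygen would move the number as benzyl does remains open.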